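The source may hold more compounds than are shown below. What is called first, only, known or untested is meant among the compounds shown, and "the series" means these compounds.

Compound 1 `CC1=CC[C@@H]([C@@](C)(O)CCCC(C)(C)NC(=S)N/N=C\c2ccccc2)CC1` in a functional assay on UACC-62 cells (Homo sapiens) for cytotoxicity, read by sulforhodamine B assay (a lower number here means that less compound is tolerated, a higher number that more compound is tolerated), gives 48400 nM. Compound 3 `CC1=CC[C@@H]([C@@](C)(O)CCCC(C)(C)NC(=S)N/N=C\c2cccc(Cl)c2)CC1` gives 42700 nM in the same test, so that compound 1 stands highest of the two plain numbers, with compound 3 nearest and separated from it only by a 1.1-fold lower number from compound 1 to compound 3 (0.05 log units; within the scatter), a gap within the scatter. Compound 2 `CC1=CC[C@@H]([C@@](C)(O)CCCC(C)(C)NC(=S)N/N=C\c2ccccc2Cl)CC1` is reported at > 100000 nM, which is a limit of this assay rather than a number. Compound 4 `CC1=CC[C@@H]([C@@](C)(O)CCCC(C)(C)NC(=S)N/N=C\c2ccc(Cl)cc2)CC1` is the member not yet measured; from compound 1 it differs by chloro in place of hydrogen on an aromatic carbon. Two measured steps carry the same kind of change. From compound 1 to compound 2 the number rises by an at least 2.0-fold higher number from compound 1 to compound 2 (0.31 log units; beyond the scatter), a step that rests on (the limit of > 100000 nM in this assay, at which 1 of the 3 values shown sits). From compound 1 to compound 3 the number moves by a 1.1-fold lower number from compound 1 to compound 3 (0.05 log units; within the scatter). For the measured compounds named here, the two chloro placements thus pull apart, one modestly upward and one not at all beyond the scatter, and no measured step speaks to the placement found in compound 4. One therefore expects a step of a 1.1-fold higher number from compound 1 to compound 4 (0.06 log units; within the scatter) in this assay, a change that should stay within the scatter. Compound 4 is estimated at 55000 nM, with a likely range from 25000 nM to 110000 nM.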

Compound 4, concentration lethal to 50% of the cells: 40600 nM
The estimate for compound 4 lay 1.4-fold (0.13 log units) above the measured number; low and high end bracket the measured number.
By their numbers in this assay, from the lowest: compounds 4, 3 and 1 (each within the scatter of the next). At a limit, above all of these: compound 2.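

Putting chloro on an aromatic carbon para to a large group, phenyl to 4-chlorophenyl, leaves the number in this assay within the scatter: a 1.2-fold lower number from compound 1 to compound 4 (0.08 log units; within the scatter). For the compounds shown here, compound 4 also cannot be told apart from the other plain chloro compound, a 1.1-fold lower number from compound 3 to compound 4 (0.02 log units; within the scatter), so this position joins that of compound 3 as a second chloro placement with no readable effect, which the earlier compounds could not show for this place on the ring. Of the chloro placements shown, only that of compound 2 stands apart, an at least 2.4-fold lower number from compound 2 to compound 4 (0.39 log units; beyond the scatter). The reading of compound 2, > 100000 nM, is a limit of this assay and not a number. The size of this step therefore stays a bound: the limit of > 100000 nM in this assay, at which 1 of the 4 values shown sits.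

The compounds shown leave open whether a group other than chloro at this same position, such as methoxy, a dimethylamino group or a carboxylic acid, would also stay within the scatter of compound 1. They also do not tell whether the core of compound 1 would respond the same way with a shorter or longer chain between the ring bearing the hydroxyl and the thiourea nitrogen.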